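Changing the group on the amine nitrogen of a shared core

The source may report more compounds than this note shows. Statements on the series, on what has been measured and on what is new or still open speak of the compounds shown alone.

Three compounds share one core and differ only in the group attached to an amine nitrogen. Compound 1 `CCOC(=O)C1=C(N/N=C(/Br)c2ccccc2)Nc2[nH]nc(C)c2C1c1ccc(N(C)C)cc1` gives 72000 nM in a functional assay on HepG2 cells (Homo sapiens) for inhibition, read by MTT assay, with a stated time of 48 h; a higher number here means a weaker inhibitor, a lower number a stronger inhibitor. Compound 2 `CCOC(=O)C1=C(N/C=N/c2nnc(S(N)(=O)=O)s2)Nc2[nH]nc(C)c2C1c1ccc(N(C)C)cc1` gives 38100 nM in this assay, and compound 3 `CCOC(=O)C1=C(N/C=N/c2ccc([N+](=O)[O-])cc2)Nc2[nH]nc(C)c2C1c1ccc(N(C)C)cc1` gives 50900 nM in this assay. Compound 3 stands second highest of these three numbers; its nearest neighbour is compound 2 and its furthest is compound 1, and both gaps lie within the scatter, so no order among the three can be read from them.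

Compound 4 `CCOC(=O)C1=C(N/N=C(/C#N)C(=O)OCC)Nc2[nH]nc(C)c2C1c1ccc(N(C)C)cc1` is not yet measured. It differs from compound 3 at the same amine nitrogen: a group of 9 heavy atoms (5 carbon, 2 nitrogen, 2 oxygen; no ring) in place of a group of 11 heavy atoms (7 carbon, 2 nitrogen, 2 oxygen; one six-membered aromatic ring of carbon only), on an amine nitrogen

Every measured step bears on this change, since each swaps the group on that nitrogen: a 1.9-fold lower number from compound 1 to compound 2 (0.28 log units; within the scatter), a 1.4-fold lower number from compound 1 to compound 3 (0.15 log units; within the scatter) and a 1.3-fold higher number from compound 2 to compound 3 (0.13 log units; within the scatter). All three lie within the scatter, even where an aromatic ring of carbon was exchanged for a five-membered aromatic ring with three hetero atoms. No step beyond the scatter is therefore expected in this assay for compound 4, in either direction, with a 1.0-fold lower number from compound 3 to compound 4 (0.01 log units; within the scatter) as the expected step. Compound 4 is estimated at 50000 nM, within a range of 20000 nM to 130000 nM.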

Compound 4, half-maximal inhibitory concentration: 46400 nM
Beside the measured number, compound 4's estimate is 1.1-fold (0.03 log units) above it; low and high end bracket the measured number.
By their numbers in this assay, from the lowest: compounds 2, 4, 3 and 1 (each within the scatter of the next).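

In this assay, the group on the amine nitrogen can lose its ring altogether and compound 4 still stays within the scatter of every earlier compound: a 1.1-fold lower number from compound 3 to compound 4 (0.04 log units; within the scatter) and a 1.2-fold higher number from compound 2 to compound 4 (0.09 log units; within the scatter) and a 1.6-fold lower number from compound 1 to compound 4 (0.19 log units; within the scatter) are the three new steps. The earlier compounds shown here showed this only for exchanges of one aromatic ring for another, whereas compound 4 carries a group with no ring and with a triple bond outside any ring. Among these four compounds, then, an aromatic ring in this group is not required for a number in this range, and no measurement at hand accounts for how closely the four numbers agree.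

What the compounds shown leave open is whether any group on this nitrogen can produce a step beyond the scatter, since a small methyl, a free amine, a carboxylic acid or a longer alkyl chain does not appear among them. All four compounds also keep the rest of the shared core unchanged, so they cannot tell how the number would respond to a change made elsewhere on the molecule.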